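Methoxy added beside the carboxymethoxy arm of compound 2

The compounds below may be only part of what the source reports. "The series", "measured", "known", "first", "only" and "open" are said of these compounds alone.

Measured so far:
compound 1, `O=C(CCCCn1cnc2c(S)ncnc21)Nc1ccc(C(=O)O)cc1`: 14%
compound 2, `CN(C1=NC(=O)/C(=C\c2ccc(OCC(=O)O)cc2)S1)c1ccc(O)cc1`: 19%

Compound 2 gives 19% in a functional assay on HEY cells (Homo sapiens) for cytotoxicity, read by MTT assay, tested at 20 uM (on this read-out lower numbers stand for less inhibition and higher numbers for more inhibition at the one concentration tested (going by the name of the read-out)), the higher of the two numbers, yet its gap to compound 1 lies within the scatter, so the two cannot be ranked. Compound 3, `COc1cc(/C=C2/SC(N(C)c3ccc(O)cc3)=NC2=O)ccc1OCC(=O)O`, differs from compound 2 by methoxy in place of hydrogen on an aromatic carbon. Among the compounds with values here, no measured pair tells the weight of such a change, so the step is expected to be small and of uncertain direction. Compound 3 is therefore estimated at 22%, between 5% and 45%, a step of a number 3 percentage points higher from compound 2 to compound 3 (within the scatter) that is expected to stay within the scatter.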

Compound 3, a percentage reported as inhibition, at one concentration (the size of the read-out at that concentration, not a potency): 12%
Estimate against measurement, compound 3: 10 percentage points above; measured number inside the range.
By their numbers in this assay, from the lowest: compounds 3, 1 and 2 (each within the scatter of the next).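

Within the data shown here, with methoxy in place of hydrogen on an aromatic carbon, ortho to a carboxymethoxy group, the pair gives the only one-place reading so far: a number 7 percentage points lower from compound 2 to compound 3 (within the scatter) in this assay leaves the two compounds unranked. This place therefore takes a methoxy group with no difference that can be told from the scatter at the one concentration tested. Nothing at hand gives a reason for this step. As far as these compounds go, whether an amine or a longer chain such as ethoxy at this place would give a step beyond the scatter stays open.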